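This account rests on a few compounds, and the source may have more. Where it says the series, first, only, none or still open, it means among the compounds named here.

Compound 2 `CCCSc1nc(N/N=C/c2cccnc2)c2nnn(Cc3ccccc3)c2n1` carries a pyridin-3-yl group on the hydrazone carbon and a benzyl group on the shared core. In a functional assay on ECa-109 cells (Homo sapiens) for antiproliferative activity, read by MTT assay, with a stated time of 72 h (on this read-out lower numbers stand for stronger inhibition and higher numbers for weaker inhibition), compound 2 gives only a limit, > 64000 nM, and no number. That limit is the limit of > 64000 nM in this assay, at which 1 of the 3 values shown sits. Among the measured compounds shown here, the two compounds with a number are compound 1 `CCCSc1nc(N/N=C(\C)c2ccccc2O)c2nnn(Cc3ccc(Cl)cc3)c2n1`, which in this assay gives 11200 nM, and compound 3 `CCCSc1nc(N/N=C(\C)c2ccccc2O)c2nnn(Cc3ccc(O)cc3)c2n1`, which in this assay gives 15900 nM; the one measured step between them, a 1.4-fold higher number from compound 1 to compound 3 (0.15 log units; within the scatter), concerns a different part of the molecule and says little about the hydrazone carbon. Compound 4 `CCCSc1nc(N/N=C/c2ccccc2)c2nnn(Cc3ccccc3)c2n1` differs from compound 2 by phenyl in place of pyridin-3-yl on a carbon with a double bond to nitrogen. For the measured compounds named here, no measured step touches this position, so the expectation rests on compound 2 alone, whose value > 64000 nM is a limit and leaves the true number open. Compound 4 is therefore expected to stay weak, with an estimated value of 50000 nM and a range from 15000 nM to 200000 nM. The expected step in this assay is an at least 1.2-fold lower number from compound 2 to compound 4 (0.10 log units; that floor lies within the scatter), with a good chance that only a limit is reported again.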

Compound 4, half-maximal inhibitory concentration: > 64000 nM
Compound 4: a limit, no number; the forecaster's own chance of this, stated with the estimate: 45%; at least 1.2-fold (0.10 log units) between middle value and limit.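

Compound 2 and compound 4 both give only a limit in this assay, so no step between them can be read: the limit of > 64000 nM in this assay, at which 2 of the 4 values shown sit.

The compounds shown leave open where the true numbers of compound 2 and compound 4 lie, and whether phenyl in place of pyridin-3-yl changes anything.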